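A few compounds are considered here, and "the series" means these few. Any claim that something is new, unique, unknown or untested is made for them only; others in the source may bear on it.

Of the compounds shown here, two have been measured in a functional assay on HT-1080 cells (Homo sapiens) for antiproliferative activity, read by sulforhodamine B assay, with a stated time of 48 h (on this read-out higher numbers stand for weaker inhibition and lower numbers for stronger inhibition), so far. Compound 1, `CC(C)C(=O)Nc1ccc(S(=O)(=O)Oc2ccccc2I)cc1`, gives 3300 nM in this assay. Compound 2, `CC(C)c1ccccc1OS(=O)(=O)c1ccc(NC(=O)C(C)(C)C)cc1`, gives 11000 nM in this assay, the highest of the two numbers; its nearest neighbour is compound 1, whose number is lower by a margin beyond the usual scatter.

Compound 3, `CC(C)(C)C(=O)Nc1ccc(S(=O)(=O)Oc2ccccc2I)cc1`, has not yet been measured. It differs from compound 2 in one place: iodo in place of isopropyl on an aromatic carbon. Within the data shown here, no direct step between measured compounds describes this change on its own, so the expectation leans on the values shown. Compound 3 carries the same iodo group that compound 1 carries, and compound 1 gives 3300 nM in this assay. Compound 3 is therefore expected to show a number lower than that of compound 2, a step estimated as a 2.4-fold lower number from compound 2 to compound 3 (0.39 log units; beyond the scatter) in this assay. The estimated value of compound 3 in this assay is 4500 nM, with an expected range from 1500 nM to 13000 nM.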

Compound 3, half-maximal inhibitory concentration: 2600 nM
The estimate for compound 3 lay 1.7-fold (0.24 log units) above the measured number; low and high end bracket the measured number.
By their numbers in this assay, from the lowest: compounds 3 and 1 (each within the scatter of the next); then compound 2.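

Iodo in place of isopropyl on this aromatic carbon, ortho to a large group, gives a 4.2-fold lower number from compound 2 to compound 3 (0.63 log units; beyond the scatter) in this assay and is the first direct reading of this change on an otherwise unchanged compound. Methyl in place of hydrogen on the saturated chain carbon bound to a carbonyl carbon and two saturated chain carbons gives a 1.3-fold lower number from compound 1 to compound 3 (0.10 log units; within the scatter) in this assay and leaves the two iodo compounds within the scatter of each other. Nothing shown here accounts for the size of either step. The compounds shown leave open how a chloro, a methoxy or an amine on this aromatic carbon would compare with iodo. They also leave open whether the iodo step would hold with the amide chain of compound 1, and how a longer chain there would read.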